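Replacing the furan ring: what solubility to expect

This account rests on a few compounds, and the source may have more. Where it says the series, first, only, none or still open, it means among the compounds named here.

Compound 1 `Cc1ccc(-c2cnn3c(NCc4ccccn4)cc(C)nc23)cc1`: in a physicochemical assay for solubility, read by HPLC, using the shake flask method, measured as kinetic solubility, with a stated time of 2 h, at pH 7.4 (a higher number here means a more soluble compound, a lower number a less soluble compound), compound 1 gives < 5000 nM, a limit of the assay rather than a number.
Compound 2 `Cc1cc(NCc2ccccn2)n2ncc(-c3ccccc3C)c2n1`: compound 2 gives < 5000 nM, again only a limit.
Compound 3 `Cc1cc(NCc2ccccn2)n2ncc(-c3ccco3)c2n1`: compound 3 gives 48800 nM.

Among the compounds with values here, compound 3 therefore holds the only real number; the other two values sit at the limit of < 5000 nM in this assay, at which 2 of the 3 values shown sit. Both steps toward it, an at least 9.7-fold higher number from compound 1 to compound 3 (0.98 log units; beyond the scatter) and an at least 9.7-fold higher number from compound 2 to compound 3 (0.98 log units; beyond the scatter), were beyond the scatter, while a step that the two limits leave unreadable from compound 1 to compound 2 cannot be read. Compound 4 `Cc1cc(NCc2ccccn2)n2ncc(-c3cccc(N(C)C)c3)c2n1` differs from compound 3 by 3-(dimethylamino)phenyl in place of furan-2-yl on an aromatic carbon. Compounds 1 and 2, which also carry a six-membered carbon ring in this place, gave only limits. A drop beyond the scatter is therefore expected for compound 4, as the step of an 8.1-fold lower number from compound 3 to compound 4 (0.91 log units; beyond the scatter). Compound 4 is estimated at 6000 nM in this assay, between 1500 nM and 25000 nM, with a fair chance that only a limit is reported.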

Compound 4, solubility: 94600 nM
The estimate for compound 4 lay 16-fold (1.20 log units) below the measured number; the whole stated range lies below it.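

Swapping furan-2-yl for 3-(dimethylamino)phenyl gives a 1.9-fold higher number from compound 3 to compound 4 (0.29 log units; within the scatter) in this assay, so a six-membered carbon ring at this place does not by itself bring the reading down to a limit. Six-membered rings at this place also differ widely from one another, with an at least 18-fold higher number from compound 2 to compound 4 (1.27 log units; beyond the scatter) and an at least 18-fold higher number from compound 1 to compound 4 (1.27 log units; beyond the scatter). These last two steps start from a limit rather than a number: the limit of < 5000 nM in this assay, at which 2 of the 4 values shown sit.

The compounds shown do not tell whether the dimethylamino group must sit where it does in 3-(dimethylamino)phenyl. On these data alone, how a 4-(dimethylamino)phenyl group or a carboxylic acid on the phenyl ring would read also stays open.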